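A Ring Exchange on the Shared Core

A few compounds are considered here, and "the series" means these few. Any claim that something is new, unique, unknown or untested is made for them only; others in the source may bear on it.

Compound 1 `CC1CCN(c2ccc(Nc3nccc(-c4cccs4)n3)cc2)CC1` and compound 2 `CN(C)c1ccc(Nc2nccc(-c3cccs3)n2)cc1` share one core and differ in a single group. In a functional assay for inhibition, with Homo sapiens as the target (a higher number here means a weaker inhibitor, a lower number a stronger inhibitor), compound 1 gives 400 nM, and compound 2 gives 900 nM. For the measured compounds named here, the one change between them, dimethylamino in place of 4-methylpiperidin-1-yl on an aromatic carbon, brought a 2.3-fold higher number from compound 1 to compound 2 (0.35 log units; beyond the scatter). Going by the values given here, compound 2 therefore stands at the highest number of the two measured, with compound 1 as its only neighbour at the lower number.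

Compound 3 `CN(C)c1ccc(Nc2nccc(-c3ccncc3)n2)cc1` has not yet been measured. It differs from compound 2 by pyridin-4-yl in place of thiophen-2-yl on an aromatic carbon. Among the compounds with values here, the single measured step altered a different group on the core, so no measured step bears on this exchange. Lacking a guide, the step of a 1.1-fold higher number from compound 2 to compound 3 (0.05 log units; within the scatter) is expected to be small, possibly not beyond the scatter. Compound 3 is expected to give about 1000 nM in this assay, with a likely range from 300 nM to 4000 nM.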

Compound 3, half-maximal inhibitory concentration: 3700 nM
The estimate for compound 3 lay 3.7-fold (0.57 log units) below the measured number, within the range that was stated.
By their numbers in this assay, from the lowest: compound 1; then compound 2; then compound 3.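

For the compounds shown here, this is the first measured sign that the ring on the shared core matters in this assay, as well as the group changed earlier: pyridin-4-yl in place of thiophen-2-yl brought a 4.1-fold higher number from compound 2 to compound 3 (0.61 log units; beyond the scatter). The two rings have the same hydrogen-bond donor and acceptor counts and no net charge, so those counts do not separate them; they differ in ring size and in their hetero atom, nitrogen against sulfur. Nothing measured here explains why the number rose.

On these data alone, with both ring size and hetero atom changing in one step, it remains open which of them goes with the rise, and a phenyl ring or a furan-2-yl ring at this place could help tell them apart. Also open, as far as these compounds go, is whether pyridin-4-yl would bring a similar step with 4-methylpiperidin-1-yl on the core.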